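Chloro for Methoxy on a Cytotoxicity Read-out

The source may hold more compounds than are shown below. What is called first, only, known or untested is meant among the compounds shown, and "the series" means these compounds.

Of the compounds shown here, three sharing one core have been tested in an ADME assay on BJ cells (Homo sapiens) for cytotoxicity, with a stated time of 72 h; on this read-out higher numbers stand for an effect only at larger amounts of compound and lower numbers for an effect already at smaller amounts. Compound 1 `COc1ccc(-c2nc3c(c(C)nn3-c3ccccc3)c(-c3ccccc3O)c2C#N)cc1` reaches only a limit of the assay, > 23000 nM. Compound 2 `CCc1ccc(-c2nc3c(c(C)nn3-c3ccccc3)c(-c3ccccc3I)c2C#N)cc1` likewise stops at a limit, > 20000 nM. Compound 3 `CCc1ccc(-c2nc3c(c(C)nn3-c3ccccc3)c(-c3ccccc3C(=O)OC)c2C#N)cc1` also gives only a limit, > 20000 nM. Among the measured compounds shown here, the single step between measured compounds, a step that the two limits leave unreadable from compound 2 to compound 3, therefore cannot be read. For the measured compounds named here, the evidence so far is summed up by the limit of > 20000 nM in this assay, at which 2 of the 3 values shown sit, and the limit of > 23000 nM in this assay, at which 1 of the 3 values shown sits: within the tested range no compound shows a numbered effect on these cells.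

Compound 4 `Cc1nn(-c2ccccc2)c2nc(-c3ccc(Cl)cc3)c(C#N)c(-c3ccccc3O)c12` differs from compound 1 in one place: chloro in place of methoxy on an aromatic carbon. Going by the values given here, no measured step bears on this change, since the only step available is unreadable, and all three measured compounds sit at limits. Compound 4 is therefore expected to resemble compound 1, whose value > 23000 nM is only a limit. The step that the limit leaves unreadable from compound 1 to compound 4 is expected to be none beyond the scatter, with compound 4 most likely again reported as a limit in this assay. For compound 4 the estimate is 30000 nM, ranging from 15000 nM to 80000 nM.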

Compound 4, half-maximal effective concentration: > 20000 nM
Compound 4: a limit, no number; the forecaster's own chance of this, stated with the estimate: 85%; the middle value lies beyond the limit too.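

Among the compounds shown here, compound 1 and compound 4 both stop at a limit in this assay, so the change from methoxy to chloro gives no readable step, and no new step follows from them. The compounds shown leave open at what concentration, if any, each of them would produce a numbered effect on these cells: the limit of > 20000 nM in this assay, at which 3 of the 4 values shown sit.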